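Swapping the basic tail on the sulfonyl of compound 1

This account rests on a few compounds, and the source may have more. Where it says the series, first, only, none or still open, it means among the compounds named here.

Measured so far:
compound 1, `CCN(CC)CCCS(=O)(=O)c1ccc2nc(NC(=O)NC(=O)c3cc(-n4cccn4)ccc3Cl)sc2c1`, 3.9 nM
compound 2, `CS(=O)(=O)c1ccc2sc(NC(=O)NC(=O)c3ccccc3Cl)nc2c1`, 4700 nM

Two compounds have been run in an assay on HEK293 cells for displacement of a labelled ligand from growth hormone secretagogue receptor type 1 (Homo sapiens), with a stated time of 60 min; on this read-out lower numbers stand for stronger inhibition and higher numbers for weaker inhibition. Compound 1 gives 3.9 nM, the lowest of the two numbers. For the measured compounds named here, compound 2 gives 4700 nM, far weaker and beyond the scatter, but it differs from compound 1 in more than one place, so the two values show only that the pair sits far apart.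

Compound 3, `CN1CCC(S(=O)(=O)c2ccc3nc(NC(=O)NC(=O)c4cc(-n5cccn5)ccc4Cl)sc3c2)CC1`, is not yet measured. It differs from compound 1 in one place: 1-methylpiperidin-4-yl in place of 3-(diethylamino)propyl on a sulfonyl sulfur. Both groups carry a single nitrogen that can accept a hydrogen bond and neither carries a net charge; the main difference is that the chain of compound 1 is replaced by a ring of similar size. Going by the values given here, with no comparable step measured, a small loss or none beyond the scatter is expected, giving an estimated step of a 1.8-fold higher number from compound 1 to compound 3 (0.25 log units; within the scatter). Compound 3 is therefore expected to give about 7 nM in this assay, within 1.5 nM to 30 nM.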

Compound 3, half-maximal inhibitory concentration: 15 nM
Compound 3: middle estimate off by 2.1-fold (0.33 log units), on the low side; the measured number falls inside the stated range.
By their numbers in this assay, from the lowest: compound 1; then compound 3; then compound 2.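

In this assay, exchanging the open 3-(diethylamino)propyl chain on the sulfonyl sulfur for the 1-methylpiperidin-4-yl ring gives a 3.8-fold higher number from compound 1 to compound 3 (0.59 log units; beyond the scatter). This single step shows that the chain is not essential at this place, since compound 3 keeps much of the activity at 15 nM, although the loss is real and goes beyond ordinary assay scatter. No measurement shown here explains why the ring gives the weaker number.

Going by these compounds, with one chain and one ring, it remains open whether the loss follows from closing the chain into a ring or from changing the groups on the nitrogen. A morpholine ring, a pyrrolidine ring or a propyl chain ending in a dimethylamino group would each help separate these two possibilities.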